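Variation of the ring-nitrogen substituent in a piperidinyl-ether series

The source may hold more compounds than are shown below. What is called first, only, known or untested is meant among the compounds shown, and "the series" means these compounds.

Compound 2 `CS(=O)(=O)c1ccc(N2CCc3c(OC4CCN(C(=O)OCCF)CC4)ncnc32)c(F)c1` and compound 1 `CC(C)COC(=O)N1CCC(Oc2ncnc3c2CCN3c2ccc(S(C)(=O)=O)cc2F)CC1` share a core and differ only at the group on the ring nitrogen. In a functional assay on CHO-K1 cells with Glucose-dependent insulinotropic receptor (Homo sapiens) as the target, read by a luciferase reporter, with a stated time of 5 h (on this read-out lower numbers stand for smaller maximal responses and higher numbers for larger maximal responses), compound 1 gives 94%, and compound 2 gives 86%, the lower of the two numbers, though a number 8 percentage points lower from compound 1 to compound 2 (within the scatter) lies within the scatter, so the two stand level.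

Compound 3 `CS(=O)(=O)c1ccc(N2CCc3c(OC4CCN(C(=S)Sc5ccccc5)CC4)ncnc32)c(F)c1` carries a group of 9 heavy atoms (7 carbon, 2 sulfur; one six-membered aromatic ring of carbon only) in place of a group of 6 heavy atoms (3 carbon, 2 oxygen, 1 fluorine; no ring), on an amine nitrogen in a ring. Among the measured compounds shown here, the only measured step, fluoromethyl in place of isopropyl on the saturated chain carbon bound to the oxygen of the carbonyl group, kept the carbonyl and ether oxygen in place and produced no change beyond the scatter. For the measured compounds named here, no measured pair covers the loss of the oxygens or the entry of a sulfur-bearing aromatic group, so the step is expected to be uncertain and possibly downward.

Compound 3 is estimated at 72% (range 35% to 100%), a step of a number 14 percentage points lower from compound 2 to compound 3 (beyond the scatter), expected but not anchored by a measured analogue.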

Compound 3, largest response reached (reported as percent of maximum), in percent of the reference or control that the assay uses: 103%
Compound 3: the middle estimate sits 31 percentage points below what was measured, outside the stated range (above it).
By their numbers in this assay, from the lowest: compounds 2, 1 and 3 (each within the scatter of the next, the first and the last beyond it).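

On the amine nitrogen in the ring, the (2-fluoroethoxy)carbonyl group of compound 2 can be replaced by a group with two sulfur atoms and a six-membered aromatic ring of carbon only, and in this assay the maximal response does not fall: the change gives a number 17 percentage points higher from compound 2 to compound 3 (beyond the scatter) as a modest gain. Set against the group of compound 1, the same replacement gives a number 9 percentage points higher from compound 1 to compound 3 (within the scatter) and so leaves the two compounds level, which shows that among these three compounds a large maximal response at this position needs neither of the oxygens of the earlier groups and is kept with an aromatic ring present. No evidence at hand bears on the origin of this step.

The compounds shown do not separate the part played by the sulfur atoms from that of the aromatic ring. As far as these compounds go, how this nitrogen behaves with a simple phenyl ester, an amine or a carboxylic acid in the group also stays open.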